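This account rests on a few compounds, and the source may have more. Where it says the series, first, only, none or still open, it means among the compounds named here.

Compound 1 `CCCS(=O)(=O)N1CC=C(c2ccc3c(c2)CC(C2CCN(c4ncc(C(F)(F)F)cn4)CC2)O3)CC1` gives 14 nM in a functional assay on HEK293 cells for agonist activity at Glucose-dependent insulinotropic receptor (Homo sapiens), read by cAMP accumulation, with a stated time of 60 min; on this read-out lower numbers stand for an effect already at smaller amounts and higher numbers for an effect only at larger amounts of compound. Compound 2 `CCCc1cnc(N2CCC(C3Cc4cc(C5=CCN(S(=O)(=O)CCC)CC5)ccc4O3)CC2)nc1` gives 82 nM in this assay, and the step between them reads a 5.9-fold higher number from compound 1 to compound 2 (0.77 log units; beyond the scatter). Compound 3 `CCCc1cnc(N2CCC(C3(C)Cc4cc(C5=CCN(S(=O)(=O)CCC)CC5)ccc4O3)CC2)nc1` gives 70 nM in this assay, the step from its neighbour being a 1.2-fold lower number from compound 2 to compound 3 (0.07 log units; within the scatter). Among the three numbers, compound 3 holds the second highest; compound 2 sits within the scatter of it and compound 1 lies further off, beyond the scatter.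

Compound 4 `CCCc1cnc(N2CCC(C3(C)Cc4cc(C5=CCN(S(=O)(=O)CCCCO)CC5)ccc4O3)CC2)nc1` differs from compound 3 by hydroxymethyl in place of hydrogen on a saturated chain carbon, three bonds along the chain from a sulfonyl sulfur. Neither measured step concerns the sulfonyl chain: one changes a group on an aromatic carbon, the other a saturated ring carbon, and the second of these stayed within the scatter. Among the measured compounds shown here, no measured step therefore bears directly on this change, so the expectation for this assay is a step no larger than the scatter, in either direction. Compound 4 is accordingly estimated at 70 nM, with a range from 25 nM to 200 nM. The expected step is no change at the digits printed from compound 3 to compound 4 (within the scatter).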

Compound 4, half-maximal effective concentration: 28 nM
Compound 4: the middle estimate sits 2.5-fold (0.40 log units) above what was measured; the range from low to high includes it.
By their numbers in this assay, from the lowest: compounds 1 and 4 (each within the scatter of the next); then compounds 3 and 2 (each within the scatter of the next).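

Among the compounds shown here, the sulfonyl chain, which no earlier step touched, proves responsive in this assay: going from propyl to 4-hydroxybutyl gives a 2.5-fold lower number from compound 3 to compound 4 (0.40 log units; beyond the scatter). Hydroxymethyl on this saturated chain carbon, three bonds along the chain from a sulfonyl sulfur, is therefore tolerated, and the number falls rather than rises, unlike the methyl step on the saturated ring carbon, which stayed within the scatter. No measurement presented here explains this step.

Open, on these data alone, is whether the hydroxyl or the longer chain carries the step, which a plain butyl chain would separate, and whether a shorter 2-hydroxyethyl chain, a carboxylic acid or an amine at the chain end would give a similar number. Also open, as far as these compounds go, is whether the same change would carry over to the trifluoromethyl series of compound 1.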